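From cyclopropyl to methyl on compound 2

The source may report more compounds than this note shows. Statements on the series, on what has been measured and on what is new or still open speak of the compounds shown alone.

compound 1 `Cc1nc(N2CCN(C)CC2)c2nc(-c3ccccc3C(F)(F)F)n(C3CCOCC3)c2n1`: 24%
compound 2 `Cc1nc(N2CCN(C)CC2)c2nc(-c3ccccc3C3CC3)n(C3CCOCC3)c2n1`: 33%

In an ADME assay (liver) for metabolic stability, with Liver microsome (Homo sapiens) as the target, read by LC-MS, using microsomes, with a stated time of 30 min, tested at 4 uM (a higher number here means that more of the compound is left, a lower number that less of the compound is left), compound 2 gives 33% and lies within the scatter of compound 1 at 24% on the two numbers available. Going from compound 2 to compound 3 `Cc1nc(N2CCN(C)CC2)c2nc(-c3ccccc3C)n(C3CCOCC3)c2n1` brings methyl in place of cyclopropyl on an aromatic carbon and leaves the rest of the structure unchanged. Among the compounds with values here, the one measured step bearing on this is a number 9 percentage points higher from compound 1 to compound 2 (within the scatter) at the same aromatic carbon, so no step beyond the scatter is expected here. The estimate is a number 4 percentage points lower from compound 2 to compound 3 (within the scatter) as the expected step. Compound 3 is estimated at 29% with 14% to 47% as the expected range.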

Compound 3, percent of the compound remaining: 18%
Estimate against measurement, compound 3: 11 percentage points above; low and high end bracket the measured number.
By their numbers in this assay, from the lowest: compounds 3, 1 and 2 (each within the scatter of the next, the first and the last beyond it).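

In this assay, this aromatic carbon now shows a step beyond the scatter, though a modest one (a number 15 percentage points lower from compound 2 to compound 3 (beyond the scatter)), so cyclopropyl and methyl do not read alike here. Methyl and trifluoromethyl, by contrast, remain within the scatter of each other (a number 6 percentage points lower from compound 1 to compound 3 (within the scatter)), so among these three groups only the cyclopropyl and methyl pair separates. Nothing available accounts for this step. The compounds shown leave open how an ethyl group, a methoxy group or an amine would read on this aromatic carbon, and whether the step holds on another core.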